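This account rests on a few compounds, and the source may have more. Where it says the series, first, only, none or still open, it means among the compounds named here.

Compound 1 `CN(CC1=CC[C@H]2C[C@@H]1C2(C)C)Cc1ccc(-c2ccccc2)cc1` gives 3160 nM in an assay on HEK293 cells for displacement of a labelled ligand from C-X-C chemokine receptor type 3 (Homo sapiens) (on this read-out lower numbers stand for stronger inhibition and higher numbers for weaker inhibition), and is the only one of the three measured compounds to yield a number at all. Compound 2 `CN(CC1=CC[C@H]2C[C@@H]1C2(C)C)Cc1ccc(-c2ccc(C(F)(F)F)cc2)cc1` reaches only the limit > 316 nM in this assay. Compound 3 `COc1ccc(-c2ccc(CN(C)CC3=CC[C@H]4C[C@@H]3C4(C)C)cc2)cc1OC` likewise shows only the limit > 316 nM in this assay. The step that the limit leaves unreadable from compound 1 to compound 2 stays unreadable because the limit of > 316 nM in this assay, at which 2 of the 3 values shown sit, hides its size. Compound 4 `CN(CC1=CC[C@H]2C[C@@H]1C2(C)C)Cc1ccc(-c2cccc(Cl)c2)cc1` differs from compound 1 by chloro in place of hydrogen on an aromatic carbon, sitting meta to a large group. Among the measured compounds shown here, no measured step bears on this change, and the two limits give neither size nor direction. The step of a 1.1-fold lower number from compound 1 to compound 4 (0.02 log units; within the scatter) is therefore expected to be no larger than the scatter. Compound 4 is estimated at 3000 nM, between 800 nM and 12000 nM.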

Compound 4, inhibition constant: 3980 nM
For compound 4 the middle estimate is 1.3-fold (0.12 log units) below the measured one; the measured number falls inside the stated range.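

In this assay, among the compounds shown here, the change from phenyl to 3-chlorophenyl gives the first step that can be read: a 1.3-fold higher number from compound 1 to compound 4 (0.10 log units; within the scatter). For the compounds shown here, a chloro at this place, meta to a large group, thus leaves the number within the scatter of the unsubstituted compound, which the earlier compounds could not show. Compound 2 and compound 3 give only a limit, so their steps cannot be read: the limit of > 316 nM in this assay, at which 2 of the 4 values shown sit.

As far as these compounds go, whether an amine or a carboxylic acid at this place would move the number beyond the scatter stays open. So does the effect of chloro elsewhere on this ring.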